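The source may hold more compounds than are shown below. What is called first, only, known or untested is meant among the compounds shown, and "the series" means these compounds.

In a physicochemical assay for solubility, read by spectrophotometry, in phosphate buffer, with a stated time of 18 h, at pH 7.4 (on this read-out lower numbers stand for lower solubility and higher numbers for higher solubility), compound 1 `CCc1ccc(-c2nc3c(c(C)nn3-c3ccccc3)c(-c3ccccc3C#N)c2C#N)cc1` gives 2400 nM and compound 2 `CCc1ccc(-c2nc3c(c(C)nn3-c3ccccc3)c(-c3ccccc3Cl)c2C#N)cc1` gives 1700 nM while compound 3 `CCc1ccc(-c2nc3c(c(C)nn3-c3ccccc3)c(-c3ccccc3C(=O)O)c2C#N)cc1` stands highest of the three at 33000 nM on these numbers. Compound 4 `CCc1ccc(-c2nc3c(c(C)nn3-c3ccccc3)c(-c3ccccc3)c2C#N)cc1` has hydrogen in place of carboxy on an aromatic carbon, which turns 2-carboxyphenyl into phenyl. Carboxy entered in two large measured steps (a 14-fold higher number from compound 1 to compound 3 (1.14 log units; beyond the scatter)) and (a 19-fold higher number from compound 2 to compound 3 (1.29 log units; beyond the scatter)) while chloro in place of cyano stayed within the scatter (a 1.4-fold lower number from compound 1 to compound 2 (0.15 log units; within the scatter)). Hydrogen enters in no measured step, so the size remains uncertain. Read backwards, those two large steps point to an expected large fall in this assay (estimated: an 18-fold lower number from compound 3 to compound 4 (1.26 log units; beyond the scatter)). Compound 4 is expected at 1800 nM (estimated range 700 nM to 4500 nM).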

Compound 4, solubility: 47000 nM
For compound 4 the middle estimate is 26-fold (1.42 log units) below the measured one; measured number outside the range, above it.
By their numbers in this assay, from the lowest: compounds 2 and 1 (each within the scatter of the next); then compounds 3 and 4 (each within the scatter of the next).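

In this assay, hydrogen in place of carboxy gives a 1.4-fold higher number from compound 3 to compound 4 (0.15 log units; within the scatter), so these two compounds cannot be told apart. Hydrogen in place of chloro gives a 28-fold higher number from compound 2 to compound 4 (1.44 log units; beyond the scatter), and hydrogen in place of cyano gives a 20-fold higher number from compound 1 to compound 4 (1.29 log units; beyond the scatter). The large gaps seen earlier therefore do not set carboxy apart alone: they divide chloro and cyano from both carboxy and hydrogen.

As far as these compounds go, whether a methyl group or an amine on this carbon would fall with chloro and cyano or with carboxy and hydrogen remains open. Nothing shown here explains the split.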